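The source may hold more compounds than are shown below. What is called first, only, known or untested is meant among the compounds shown, and "the series" means these compounds.

Compound 1, `COc1ccc(-n2c(SCc3ccccc3)nnc2-c2cc(OC)c(OC)c(OC)c2)cc1`: in a functional assay on HepG2 cells (Homo sapiens) for inhibition, read by MTT assay, with a stated time of 48 h (a lower number here means a stronger inhibitor, a higher number a weaker inhibitor), compound 1 gives > 60000 nM, which is a limit of the assay rather than a number.
Compound 2, `COc1ccc(CSc2nnc(-c3cc(OC)c(OC)c(OC)c3)n2-c2ccc(OC)cc2)cc1`: in this assay compound 2 gives 41100 nM.
Compound 3, `COc1ccc(-n2c(SCC(=O)c3ccccc3)nnc2-c2cc(OC)c(OC)c(OC)c2)cc1`: in this assay compound 3 gives 16200 nM.

The change under study is methoxy in place of hydrogen on an aromatic carbon. Between the two measured compounds it gave an at least 1.4-fold lower number from compound 1 to compound 2 (0.16 log units; that floor lies within the scatter). Since the reading for compound 1 is a limit, (the limit of > 60000 nM in this assay, at which 1 of the 3 values shown sits), only a floor for that step is known, and that floor lies within the scatter.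

The core of compound 3 differs from the core of compound 1 by benzoyl in place of phenyl on a saturated chain carbon bound to a sulfur. That change produced an at least 3.7-fold lower number from compound 1 to compound 3 (0.56 log units; beyond the scatter), and the related change from the methoxy-bearing analogue produced a 2.5-fold lower number from compound 2 to compound 3 (0.40 log units; beyond the scatter). Compound 3 thus holds the lowest number of the two that are numbers, with compound 2 as its nearest neighbour.

Compound 4, `COc1ccc(C(=O)CSc2nnc(-c3cc(OC)c(OC)c(OC)c3)n2-c2ccc(OC)cc2)cc1`, differs from compound 3 by methoxy in place of hydrogen on an aromatic carbon. The place is described in the same words as for the earlier pair, so this is the same change, now made on the benzoyl-bearing core.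

For compound 4 in this assay the expected step is a 1.4-fold lower number from compound 3 to compound 4 (0.13 log units; within the scatter), resting on the earlier step of an at least 1.4-fold lower number from compound 1 to compound 2 (0.16 log units; that floor lies within the scatter), whose known floor sits within the scatter. Compound 4 is therefore estimated at about 12000 nM. The plausible range for compound 4 is expected to run from an estimated 5000 nM to an estimated 30000 nM.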

Compound 4, half-maximal inhibitory concentration: 18100 nM
Compound 4: the middle estimate sits 1.5-fold (0.18 log units) below what was measured; the measured number falls inside the stated range.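

On the benzoyl-bearing core in this assay, the methoxy change gave a 1.1-fold higher number from compound 3 to compound 4 (0.05 log units; within the scatter) and so left the two readings within the scatter of each other, while the side chain of compound 4 still compares well with those lacking the carbonyl, with a 2.3-fold lower number from compound 2 to compound 4 (0.36 log units; beyond the scatter) for (4-methoxyphenyl)carbonyl in place of 4-methoxyphenyl and an at least 3.3-fold lower number from compound 1 to compound 4 (0.52 log units; beyond the scatter) for (4-methoxyphenyl)carbonyl in place of phenyl. Setting the methoxy change on the two cores side by side therefore shows no step beyond the scatter on either core, but it does not settle whether the change behaves alike on both: the same change on two cores in this assay, an at least 1.4-fold lower number (0.16 log units; that floor lies within the scatter) from compound 1 to compound 2 and a 1.1-fold higher number (0.05 log units; within the scatter) from compound 3 to compound 4; the limit leaves it open whether they differ. The comparison is open-ended on one side, so the series shows neither that the change carries from one core to the other nor that it fails to, since the step on the first core starts from a reading that is only a limit: the limit of > 60000 nM in this assay, at which 1 of the 4 values shown sits.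

The compounds shown leave open whether a chlorine, a hydroxyl or an amine in place of that methoxy on the aromatic carbon would give a step beyond the scatter. They also leave open how a longer chain or a carboxylic acid in place of the benzoylmethyl group on the sulfur would read.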